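Benzylamino sulfonamides: estimate for compound 4 on pancreatic cells

A few compounds are considered here, and "the series" means these few. Any claim that something is new, unique, unknown or untested is made for them only; others in the source may bear on it.

Measured so far in a functional assay on PANC-1 cells (Homo sapiens) for inhibition, read by MTT assay, with a stated time of 72 h; on this read-out higher numbers stand for weaker inhibition of growth and lower numbers for stronger inhibition of growth:
compound 1 `O=S(=O)(NCCCNCc1ccccc1Cl)c1cc(C(F)(F)F)cc(C(F)(F)F)c1` gives 15000 nM;
compound 2 `CC(C)(C)c1ccc(CNCCCNS(=O)(=O)c2cc(C(F)(F)F)cc(C(F)(F)F)c2)cc1` gives 2500 nM;
compound 3 `O=S(=O)(NCCCCNCc1ccc(Br)cc1)c1cc(C(F)(F)F)cc(C(F)(F)F)c1` gives 2200 nM.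

Compound 3 gives the lowest number of the three, but compound 2 sits within the scatter of it; only compound 1 is separated from it beyond the scatter. Compound 4 `O=S(=O)(NCCCNCc1ccc(Cl)c(Cl)c1)c1cc(C(F)(F)F)cc(C(F)(F)F)c1` differs from compound 3 by (3,4-dichlorobenzyl)amino in place of ((4-bromobenzyl)amino)methyl on a saturated chain carbon, three bonds along the chain from a sulfonamide nitrogen. Going by the values given here, the steps that bear on this are a 6.0-fold lower number from compound 1 to compound 2 (0.78 log units; beyond the scatter) and a 6.8-fold lower number from compound 1 to compound 3 (0.83 log units; beyond the scatter), both modest and in the same direction. Compound 4 keeps a halogenated benzyl on the shorter chain, so in this assay the estimated step of a 1.4-fold higher number from compound 3 to compound 4 (0.13 log units; within the scatter) is a small rise in number, close to the scatter. Compound 4 is estimated at 3000 nM, in the range 1200 nM to 8000 nM.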

Compound 4, concentration for 50% growth inhibition: 5600 nM
Beside the measured number, compound 4's estimate is 1.9-fold (0.27 log units) below it; low and high end bracket the measured number.
By their numbers in this assay, from the lowest: compounds 3 and 2 (each within the scatter of the next); then compound 4; then compound 1.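

In this assay, a 2.7-fold lower number from compound 1 to compound 4 (0.43 log units; beyond the scatter) and a 2.2-fold higher number from compound 2 to compound 4 (0.35 log units; beyond the scatter) show that 3,4-dichlorophenyl recovers only part of the gain seen with 4-(tert-butyl)phenyl on this chain. Halogen on the aromatic ring therefore does not by itself set the level here. Placing (3,4-dichlorobenzyl)amino where ((4-bromobenzyl)amino)methyl stood is not neutral either: a 2.5-fold higher number from compound 3 to compound 4 (0.41 log units; beyond the scatter) separates the two.

Open, from the compounds shown here alone, is how a nitrile or methoxy in place of the chlorines would read, and whether 3,4-dichlorophenyl shifts on a longer chain. No measured evidence accounts for these steps.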